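Tetrazole side chain swap: butylcarbamoyl chain to phenylpropyl amide

The source may hold more compounds than are shown below. What is called first, only, known or untested is meant among the compounds shown, and "the series" means these compounds.

Compound 1 `CC(C)(N)C(=O)N[C@H](COCc1ccccc1)c1nnnn1CCCc1ccccc1` in an assay on isolated protein for displacement of a labelled ligand from growth hormone secretagogue receptor type 1 (Homo sapiens), with a stated time of 1 h (on this read-out higher numbers stand for weaker inhibition and lower numbers for stronger inhibition), gives 200 nM.
Compound 2 `CC(C)(N)C(=O)N[C@H](COCc1ccccc1)c1nnnn1CCCCCNS(C)(=O)=O` reaches only a limit of the assay, > 5000 nM.
Compound 3 `CCCCNC(=O)CCCn1nnnc1[C@@H](COCc1ccccc1)NC(=O)C(C)(C)N` gives 1780 nM.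

Compound 3 has the highest number of the two measured values, with compound 1 nearest; the step of an 8.9-fold higher number from compound 1 to compound 3 (0.95 log units; beyond the scatter) lies beyond the scatter, and an at least 2.8-fold lower number from compound 2 to compound 3 (0.44 log units; beyond the scatter) goes the other way. Compound 4 `CC(C)(N)C(=O)N[C@H](COCc1ccccc1)c1nnnn1CCC(=O)NCCCc1ccccc1` differs from compound 3 by (3-phenylpropyl)carbamoyl in place of (butylcarbamoyl)methyl on a saturated chain carbon, two bonds along the chain from an aromatic nitrogen. Both earlier steps bear on this: a phenyl on this side chain gave the strongest binding, as in compound 1, while its loss to a butylcarbamoyl cost an 8.9-fold higher number from compound 1 to compound 3 (0.95 log units; beyond the scatter). Compound 4 brings a phenyl back at the chain end, so a moderate gain toward compound 1 is expected, a 2.2-fold lower number from compound 3 to compound 4 (0.35 log units; beyond the scatter). Compound 4 is estimated at 800 nM, between 250 nM and 3000 nM.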

Compound 4, inhibition constant: 820 nM
The estimate for compound 4 lay 1.0-fold (0.01 log units) below the measured number; measured number inside the range.
By their numbers in this assay, from the lowest: compound 1; then compound 4; then compound 3. At a limit, above all of these: compound 2.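

Putting a phenyl ring back at the chain end as (3-phenylpropyl)carbamoyl recovers only part of the lost binding: there is a 2.2-fold lower number from compound 3 to compound 4 (0.34 log units; beyond the scatter), yet still a 4.1-fold higher number from compound 1 to compound 4 (0.61 log units; beyond the scatter). A phenyl ring on this side chain therefore does not by itself restore the binding of compound 1, and the carbamoyl-containing chain still falls short. The gap to compound 2 is only a bound, an at least 6.0-fold lower number from compound 2 to compound 4 (0.78 log units; beyond the scatter), and compound 2 itself stands at a limit of the assay: the limit of > 5000 nM in this assay, at which 1 of the 4 values shown sits.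

Going by these compounds, whether a pyridine or cyclohexyl ring at the chain end would serve as well as phenyl stays open.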